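A few compounds are considered here, and "the series" means these few. Any claim that something is new, unique, unknown or untested is made for them only; others in the source may bear on it.

Measured compounds:
compound 1, `CC1=C(C(=O)Nc2ccc(F)cc2)C(c2ccc([N+](=O)[O-])cc2)N=C(SCc2ccccc2)N1`, 27.3%
compound 2, `CC1=C(C(=O)Nc2ccc(F)cc2)C(c2ccc([N+](=O)[O-])cc2)N=C(SCc2ccccc2Cl)N1`, 13.9%
compound 3, `CC1=C(C(=O)Nc2ccc(Br)cc2)C(c2ccc(Cl)cc2Cl)N=C(SCc2ccccc2)N1`, 11.3%

These three compounds were tested in a functional assay on the whole organism (artery, strain albino) with Rattus norvegicus as the target, with a stated time of 720 min, at a dose of 10 mg/kg by the oral route; on this read-out higher numbers stand for more inhibition at the one dose given (going by the name of the read-out) and lower numbers for less inhibition. Compound 1 and compound 2 share a core and differ only by chloro in place of hydrogen on an aromatic carbon; that change gave a number 13.4 percentage points lower from compound 1 to compound 2 (beyond the scatter). Compound 3 carries a different core, and the difference between the two cores is not broken down here. What the values show is that compound 3 and compound 2 lie within the usual scatter of each other, while compound 1 sits above compound 3 by more than the scatter.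

Compound 4, `CC1=C(C(=O)Nc2ccc(Br)cc2)C(c2ccc(Cl)cc2Cl)N=C(SCc2ccccc2Cl)N1`, is not yet measured in this assay. It differs from compound 3 by chloro in place of hydrogen on an aromatic carbon, the same change that separates compound 1 from compound 2, with the chlorine entering at the same kind of place, ortho to a large group on the benzyl ring. Within the data shown here, only that one earlier step is available to guide an expectation. The step from compound 3 to compound 4 is expected to be a number 5.3 percentage points lower from compound 3 to compound 4 (within the scatter), a smaller downward move than the earlier one, because compound 3 already starts from 11.3% and inhibition cannot fall far below nothing. Compound 4 is therefore expected to give 6% in this assay, with a likely range from 0% to 18%.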

Compound 4, a percentage reported as inhibition, in the whole organism at one dose (the size of the read-out at that dose, not a potency): 20.6%
For compound 4 the middle estimate is 14.6 percentage points below the measured one; the measured number lies above the stated range.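

On the second core, the change from benzyl to 2-chlorobenzyl gave a number 9.3 percentage points higher from compound 3 to compound 4 (within the scatter) in this assay, so on this core the step cannot be told apart from the usual scatter. The clear fall seen with the same change on the first core therefore did not carry over, and the two steps differ by more than two such steps would be expected to: the same change on two cores in this assay, a number 13.4 percentage points lower (beyond the scatter) from compound 1 to compound 2 and a number 9.3 percentage points higher (within the scatter) from compound 3 to compound 4, 22.7 percentage points apart, beyond the scatter of two such steps This shows that the effect of this chloro group in this series cannot be taken from one core to the other, but with a single pair on each core it does not show which part of the cores is responsible, since they differ in more than one place, a fluoro group against a bromo group and a nitro group against two chloro groups.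

The compounds shown leave open whether a core carrying only one of those differences would follow compound 1 and compound 2 or compound 3 and compound 4. They also leave open how a methoxy group or an amine on the benzyl ring would behave on either core, or a longer chain in place of the benzyl group on the sulfur.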